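The source may report more compounds than this note shows. Statements on the series, on what has been measured and on what is new or still open speak of the compounds shown alone.

In an ADME assay on HepG2 cells (Homo sapiens) for cytotoxicity (a higher number here means that more compound is needed for the effect, a lower number that less compound is needed), compound 1 (`COc1cc(OC)cc(C(=O)NCCNC(=O)[C@H](CC(=O)NC(C)(C)C)NS(=O)(=O)c2ccc(C)cc2)c1`) gives > 11000 nM as a limit of the assay, not a number. Compound 2 (`Cc1ccc(S(=O)(=O)N[C@@H](CC(=O)NC(C)(C)C)C(=O)NCCNC(=O)c2cc(C)ccn2)cc1`) gives > 11000 nM and this too is only a limit. Compound 3 (`C#Cc1cccc(C(=O)NCCNC(=O)[C@H](CC(=O)NC(C)(C)C)NS(=O)(=O)c2ccc(C)cc2)c1`) has 3-ethynylphenyl in place of 4-methylpyridin-2-yl on a carbonyl carbon. Going by the values given here, the one measured step bearing on this (a step that the two limits leave unreadable from compound 1 to compound 2) has no readable size, and the evidence so far is the limit of > 11000 nM in this assay, at which 2 of the 2 values shown sit, alone. In this assay no step beyond the scatter is therefore expected, and the estimated step (a step that the limit leaves unreadable from compound 2 to compound 3) stays within it. For compound 3 the expected value is 15000 nM with an estimated range from 6000 nM to 40000 nM and a report as a limit is likely.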

Compound 3, half-maximal effective concentration: > 11000 nM
Compound 3: no number, only a limit; the forecaster's own chance of this, stated with the estimate: 85%; the middle value is on the limit's open side.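

In this assay, going by these compounds alone, compound 1, compound 2 and compound 3 are each reported only as a limit, so no step among them can be read. As far as these compounds go, whether their 3,5-dimethoxyphenyl, 4-methylpyridin-2-yl and 3-ethynylphenyl groups separate them at all remains open.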